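Swapping the Pyridine for a Saturated Ring

The source may report more compounds than this note shows. Statements on the series, on what has been measured and on what is new or still open speak of the compounds shown alone.

Two ureas built on a shared core have been tested in a functional assay on Shh Light II cells (Mus musculus) for inhibition, read by a luciferase reporter; on this read-out lower numbers stand for stronger inhibition and higher numbers for weaker inhibition. Compound 1 `O=C(Nc1ccccc1C(F)(F)F)N1CCC(c2nc(-c3ccc4ccccc4n3)no2)CC1` gives 700 nM. Going by the values given here, compound 2 `O=C(Nc1ncccc1Cl)N1CCC(c2nc(-c3ccc4ccccc4n3)no2)CC1` gives 2800 nM, the highest of the two numbers and thus the weaker inhibitor; the single change between them, a 4.0-fold higher number from compound 1 to compound 2 (0.60 log units; beyond the scatter), is the only measured step in this set. Compound 3 `O=C(NC1CCCCC1)N1CCC(c2nc(-c3ccc4ccccc4n3)no2)CC1` has not yet been measured. It differs from compound 2 in one place: cyclohexyl in place of 3-chloropyridin-2-yl on an amide-type nitrogen. Among the compounds with values here, no measured step covers a six-membered aromatic ring with 1 hetero atom giving way to a six-membered non-aromatic ring of carbon only, so the modest step from compound 1 to compound 2 bears on it only loosely, as a sign that the group on this amide-type nitrogen shifts the number within a limited span. The expectation for compound 3 is therefore a small step of a 1.4-fold lower number from compound 2 to compound 3 (0.15 log units; within the scatter), possibly within the scatter. Compound 3 is estimated at 2000 nM, within a range from 500 nM to 8000 nM.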

Compound 3, half-maximal inhibitory concentration: 57 nM
Compound 3: middle estimate off by 35-fold (1.55 log units), on the high side, outside the stated range (below it).
By their numbers in this assay, from the lowest: compound 3; then compound 1; then compound 2.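

In this assay, cyclohexyl on this amide-type nitrogen gives a 49-fold lower number from compound 2 to compound 3 (1.69 log units; beyond the scatter), and a 12-fold lower number from compound 1 to compound 3 (1.09 log units; beyond the scatter). The first two compounds hinted at only a modest influence from this group, whereas these steps show that the choice of group here can move the number much further, and that an aromatic ring is not needed for strong inhibition in this series. No measurement shown here explains why cyclohexyl does so much better than either aromatic group.

Both aromatic groups carry a further substituent and cyclohexyl carries none, so these compounds cannot separate the loss of aromatic character from the loss of that substituent, a question that unsubstituted phenyl would address. As far as these compounds go, how far the gain extends to a smaller ring such as cyclopentyl, an open chain such as n-hexyl, or a ring containing oxygen such as tetrahydropyran-4-yl also remains open.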